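The source may hold more compounds than are shown below. What is called first, only, known or untested is meant among the compounds shown, and "the series" means these compounds.

Measured in a functional assay on A549 cells (Homo sapiens) for inhibition, read by sulforhodamine B assay, with a stated time of 74 h; a higher number here means a weaker inhibitor, a lower number a stronger inhibitor:
compound 1 `Cc1ccc(S(=O)(=O)N2C(=O)COC23C=CC(=O)C=C3)cc1`: 110 nM
compound 2 `CS(=O)(=O)N1C(=O)COC12C=CC(=O)C=C2`: > 10000 nM (a limit)
compound 3 `O=C1C=CC2(C=C1)OCC(=O)N2S(=O)(=O)c1ccc(Cl)cc1`: > 10000 nM (a limit)

Compound 3 has no number and stands only at the limit of > 10000 nM in this assay, at which 2 of the 3 values shown sit.

The next compound is compound 4 `COc1ccc(S(=O)(=O)N2C(=O)COC23C=CC(=O)C=C3)cc1`, with the change methoxy in place of chloro on an aromatic carbon, para to a large group.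

The measured step closest to this one is an at least 90-fold higher number from compound 1 to compound 3 (1.95 log units; beyond the scatter), a large step beyond the scatter, made at the same kind of aromatic carbon with chloro in place of methyl. Also large is an at least 90-fold higher number from compound 1 to compound 2 (1.95 log units; beyond the scatter), with methyl in place of 4-methylphenyl on the sulfonyl sulfur. Compound 4 keeps an aromatic ring on that sulfur. The remaining step, a step that the two limits leave unreadable from compound 2 to compound 3, adds nothing.

Going by the values given here, only one substituent at this aromatic carbon has given a number so far, and the data do not show whether methoxy will follow methyl or chloro. The expectation rests on compound 1 at 110 nM, and it is for a large move toward a lower number, with a stronger inhibitor as the result, though probably not a full return to that level. The expected step is an at least 20-fold lower number from compound 3 to compound 4 (1.30 log units; beyond the scatter). For compound 4 the estimate is 500 nM, with an expected range of 80 nM to 5000 nM.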

Compound 4, half-maximal inhibitory concentration: > 10000 nM
Compound 4: only a limit was reported; the forecaster's own chance of this, stated with the estimate: 25%; middle value at least 20-fold (1.30 log units) away from the limit.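

In this assay, methoxy in place of methyl on the aromatic carbon gives an at least 90-fold higher number from compound 1 to compound 4 (1.95 log units; beyond the scatter), so a second replacement of the methyl of compound 1 ends in the same large loss as chloro did. Compound 4 has only a limit, > 10000 nM, and not a number. Methyl is now the only one of the three substituents shown at this aromatic carbon, para to a large group, to give a number, while the steps between the compounds held at the limit cannot be read: the limit of > 10000 nM in this assay, at which 3 of the 4 values shown sit.

The compounds shown leave open whether the activity of compound 1 belongs to methyl alone or would persist with an ethyl group or with plain hydrogen at this carbon. With a single number in the set, they also cannot rank chloro against methoxy, and they do not show how an amine or a carboxylic acid at the same carbon would compare with methyl.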